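Methoxy to hydroxy on a shared core

The source may report more compounds than this note shows. Statements on the series, on what has been measured and on what is new or still open speak of the compounds shown alone.

Compound 1, `COc1cc(-c2nn(-c3cccc(NC(=O)c4ccc(Cl)c(C(F)(F)F)c4)c3)cc2-c2ccncc2)ccc1Cl`: in a functional assay on SNB-75 cells (Homo sapiens) for inhibition, read by sulforhodamine B assay, with a stated time of 48 h (a lower number here means that less compound is tolerated, a higher number that more compound is tolerated), compound 1 gives > 32500 nM, a limit of the assay.
Compound 2, `COc1cc(-c2nn(-c3cccc(NC(=O)Nc4ccc(Cl)c(C(F)(F)F)c4)c3)cc2-c2ccncc2)ccc1Cl`: in this assay compound 2 gives > 32500 nM, likewise a limit.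

Compound 2 thus stands at a limit of the assay. The step that the two limits leave unreadable from compound 1 to compound 2 cannot be read. Compound 3, `O=C(Nc1cccc(-n2cc(-c3ccncc3)c(-c3ccc(Cl)c(O)c3)n2)c1)Nc1ccc(Cl)c(C(F)(F)F)c1`, differs from compound 2 by hydrogen in place of methyl on an oxygen on an aromatic ring, that is methoxy to hydroxy. Among the compounds with values here, no measured step bears readably on this change; the only guide is the limit of > 32500 nM in this assay, at which 2 of the 2 values shown sit. Compound 3 is therefore expected to stay near that limit, estimated at 40000 nM, within 15000 nM to 100000 nM, an expected step that the limit leaves unreadable from compound 2 to compound 3 not beyond the scatter.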

Compound 3, concentration lethal to 50% of the cells: > 32500 nM
Compound 3 was reported as a limit; the forecaster's own chance of this, stated with the estimate: 70%; the middle value does not contradict the limit.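

In this assay compound 3 gives > 32500 nM, again a limit of the assay, so no step can be read between compound 2 and compound 3. The compounds shown leave open whether methoxy to hydroxy changes the lethal concentration at all.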